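The source may report more compounds than this note shows. Statements on the series, on what has been measured and on what is new or still open speak of the compounds shown alone.

Measured so far:
- compound 1 `O=C1NC(=S)S/C1=C\C=C\c1ccccc1OCc1ccccc1C(F)(F)F`: 40.8%
- compound 2 `O=C1NC(=S)S/C1=C\C=C\c1ccccc1OCc1ccncc1`: 39.4%
- compound 3 `O=C1NC(=S)S/C1=C\C=C\c1cccnc1`: 47.1%

In an assay on isolated protein for inhibition of protein tyrosine phosphatase type IVA 3 (Homo sapiens), tested at 5 ug/mL (a higher number here means more inhibition at the concentration tested (going by the name of the read-out), a lower number less inhibition), compound 2 gives the lowest of the three numbers, yet compound 1 and compound 3 lie within the usual scatter of it, so no order among the three can be read from these values. Compound 4 `O=C1NC(=S)S/C1=C\C=C\c1ccccc1O` differs from compound 2 in one place: hydrogen in place of (pyridin-4-yl)methyl on an oxygen on an aromatic ring. Whether that exchange of (pyridin-4-yl)methyl for hydrogen matters is not known from any measured pair. Since all three measured compounds fall close together despite their different side groups, the step from compound 2 to compound 4 is expected to be small, a number 1.4 percentage points lower from compound 2 to compound 4 (within the scatter), not clearly beyond the scatter. Compound 4 is therefore estimated at 38%, in the range 22% to 54%.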

Compound 4, a percentage reported as inhibition, at one concentration (the size of the read-out at that concentration, not a potency): 51.9%
Beside the measured number, compound 4's estimate is 13.9 percentage points below it; the measured number falls inside the stated range.
By their numbers in this assay, from the lowest: compounds 2, 1, 3 and 4 (each within the scatter of the next, the first and the last beyond it).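

In this assay, hydroxy in place of (pyridin-4-yl)methoxy gives a number 12.5 percentage points higher from compound 2 to compound 4 (beyond the scatter) in the first pair shown that differs in one place. So the group on this oxygen does affect the number, and in this pair (pyridin-4-yl)methyl is not needed for inhibition at the concentration tested. Nothing shown gives a reason for the step. From the compounds shown here alone, it remains open whether the free hydroxy itself matters or only the absence of the larger group. A small methoxy, or a short chain ending in an amine or a carboxylic acid, could help separate the two.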